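Adding a chloro group to the phenyl of compound 2

The compounds below may be only part of what the source reports. "The series", "measured", "known", "first", "only" and "open" are said of these compounds alone.

Measured so far:
- Compound 1, `COc1cccc(CCCC(=O)Nc2nc3ccccc3c(=O)s2)c1`: 22.5 nM
- Compound 2, `O=C(C/C=C/c1ccccc1)Nc1nc2ccccc2c(=O)s1`: 53 nM

Both compounds share the same core and were tested in an assay on membranes from brain for displacement of a labelled ligand from adenosine receptor A1 (Rattus norvegicus), read by scintillation counting, with a stated time of 90 min; on this read-out lower numbers stand for stronger inhibition and higher numbers for weaker inhibition. Compound 2 gives the higher of the two numbers, and its gap to compound 1 lies beyond the usual scatter, so on these two results compound 2 is the weaker binder.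

Compound 3, `O=C(C/C=C/c1cccc(Cl)c1)Nc1nc2ccccc2c(=O)s1`, has not yet been measured. It differs from compound 2 in one place: chloro in place of hydrogen on an aromatic carbon. The rest of the molecule is unchanged.

No pair of measured compounds differs in a single place, so nothing shown tells how a single change of this kind shifts the result. For the measured compounds named here, the only hint is that compound 1, which carries a small group on its phenyl, gives the lower number, 22.5 nM. On that thin basis a small step toward a lower number, or none beyond the scatter, is expected in this assay for compound 3.

Compound 3 is therefore estimated at 35 nM, with a range from 12 nM to 100 nM, which means an expected step of a 1.5-fold lower number from compound 2 to compound 3 (0.18 log units; within the scatter).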

Compound 3, inhibition constant: 11.4 nM
Beside the measured number, compound 3's estimate is 3.1-fold (0.49 log units) above it, and the stated range ends above it.
By their numbers in this assay, from the lowest: compounds 3 and 1 (each within the scatter of the next); then compound 2.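

In this assay, for the compounds shown here, the change from phenyl to 3-chlorophenyl gives the first reading of a single change in this set: a 4.6-fold lower number from compound 2 to compound 3 (0.67 log units; beyond the scatter) is a modest step, but it lies beyond the scatter. It shows that this aromatic carbon, meta to a large group, accepts a chloro in place of hydrogen without any loss of binding, and that the number moves toward stronger inhibition. A single added heavy atom, with no ring, no charge and no hydrogen-bond donors or acceptors, is enough for a shift of this size, yet nothing available explains how the chloro produces it, so the step stands only as an observed change in the number.

The compounds shown leave open whether this step belongs to this particular carbon, as only one placement of the chloro on the phenyl appears here. They also leave open whether a different group on the same carbon, such as fluoro, an amine or a carboxylic acid, would move the number the same way, move it the other way, or leave it unchanged.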